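Methoxy in place of methyl on compound 3

The source may report more compounds than this note shows. Statements on the series, on what has been measured and on what is new or still open speak of the compounds shown alone.

Compound 1 `COC(=O)NC1=NC(c2cccc(C)c2)CN1` stands at 100 mg/kg in a functional assay on the whole organism for antagonist activity, with Mus musculus as the target, in the maximal electroshock model (a higher number here means that more compound is needed for the effect, a lower number that less compound is needed), and compound 2 `COC(=O)NC1=NC(c2ccccc2C)CN1C` stands at 68 mg/kg in the same read-out. Compound 3 `COC(=O)NC1=NC(c2cccc(C)c2)CN1C` stands at 89 mg/kg and lies within the scatter of both. Compound 4 `COC(=O)NC1=NC(c2cccc(OC)c2)CN1C` carries methoxy in place of methyl on an aromatic carbon, meta to a large group (methoxy in place of methyl on an aromatic carbon). For the measured compounds named here, the single measured step, methyl in place of hydrogen on an amine nitrogen in a ring, shows a 1.1-fold lower number from compound 1 to compound 3 (0.05 log units; within the scatter) and does not touch that aromatic carbon. Going by the values given here, no measured step covers methoxy, so no shift beyond the scatter is expected in this assay and no direction is favoured. An expected step of a 1.0-fold lower number from compound 3 to compound 4 (0.02 log units; within the scatter) is therefore estimated. For compound 4 the estimate is 85 mg/kg with 45 mg/kg to 160 mg/kg as the expected range.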

Compound 4, dose for half-maximal effect: 128 mg/kg
Compound 4: middle estimate off by 1.5-fold (0.18 log units), on the low side; the measured number falls inside the stated range.
By their numbers in this assay, from the lowest: compounds 2, 3, 1 and 4 (each within the scatter of the next).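

Methoxy in place of methyl on an aromatic carbon, meta to a large group, gives a 1.4-fold higher number from compound 3 to compound 4 (0.16 log units; within the scatter) in this assay and so stays within the scatter. For the compounds shown here, this is the first reading at this aromatic carbon, as the earlier step changed only the ring amine nitrogen, and here one hydrogen-bond acceptor enters without a shift beyond the scatter. No available evidence bears on this result.

Open, from the compounds shown here alone, is whether an amine, a carboxylic acid or a longer alkoxy chain on this aromatic carbon would move the number beyond the scatter.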